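Stripping the ester from a weak inhibitor

The source may hold more compounds than are shown below. What is called first, only, known or untested is meant among the compounds shown, and "the series" means these compounds.

Compound 1 `O=c1c2c(sn1-c1cc(OC3CCCC3)c(Cl)cc1F)CCCC2` gives 12900 nM
Compound 2 `CC(C)OC(=O)c1cc(-n2c(=O)c3c([s+]2[O-])CCCC3)ccc1Cl` gives 51300 nM
Compound 3 `O=c1c2c([s+]([O-])n1-c1cc(OC3CCCC3)c(Cl)cc1F)CCCC2` gives 7240 nM

All three values come from a functional assay on the whole organism for inhibition, with Scenedesmus acutus as the target, with a stated time of 20 min; a higher number here means a weaker inhibitor, a lower number a stronger inhibitor. Compound 2 has the highest of the three numbers and is the weakest inhibitor here, lying beyond the scatter of both compound 1 and compound 3.

Compound 4 `O=c1c2c([s+]([O-])n1-c1ccc(Cl)cc1)CCCC2` has not yet been measured. It differs from compound 2 in one place: hydrogen in place of isopropoxycarbonyl on an aromatic carbon. Hydrogen stands in place of isopropoxycarbonyl on an aromatic carbon, ortho to a chloro group.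

Going by the values given here, no measured pair isolates this change, so the data do not show its size. Among the compounds with values here, compound 2 at 51300 nM still carries the isopropoxycarbonyl group, whereas compound 4 keeps only the chloro group on that aromatic ring, and no measured compound has a ring so sparsely substituted. A modest move towards a higher number in this assay is therefore expected, although a result within the scatter of compound 2 would not be surprising. The expected change is a 1.6-fold higher number from compound 2 to compound 4 (0.19 log units; within the scatter). For compound 4 the estimated value is 80000 nM, with an expected range of 25000 nM to 250000 nM.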

Compound 4, half-maximal inhibitory concentration: 30200 nM
The estimate for compound 4 lay 2.6-fold (0.42 log units) above the measured number, within the range that was stated.
By their numbers in this assay, from the lowest: compounds 3 and 1 (each within the scatter of the next); then compounds 4 and 2 (each within the scatter of the next).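

Within this assay, hydrogen in place of isopropoxycarbonyl on an aromatic carbon, ortho to a chloro group, gives a 1.7-fold lower number from compound 2 to compound 4 (0.23 log units; within the scatter), so this pair cannot be separated in this read-out even though the group that leaves carries 6 heavy atoms and 2 hydrogen-bond acceptors. Going by these compounds alone, this is the first direct reading at this position: on this scaffold, the isopropoxycarbonyl group is not required to keep inhibition at the level seen for compound 2, and the sparsely substituted ring of compound 4 does not produce a clear step in either direction. No supporting measurement bears on why the two compounds read alike.

Within the data shown here, the single pair tests only hydrogen against isopropoxycarbonyl, so it remains open whether a carboxylic acid, an amine or a longer alkyl ester on the same aromatic carbon would also stay within the scatter of these two compounds or would separate from them. As far as these compounds go, it is also open whether the same replacement would read alike on the core of compound 3, which carries a cyclopentyloxy group and a fluoro group on its aromatic ring.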